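Phenyl for Methyl on the Ether Chain: Expected Solubility

The compounds below may be only part of what the source reports. "The series", "measured", "known", "first", "only" and "open" are said of these compounds alone.

Compound 1 `CCOc1cc(CN2CCC(NC(=O)c3ccc(N)nc3)CC2)cc(OCC)c1-c1ccc(F)cc1` gives 123 ug/mL in a physicochemical assay for solubility, in phosphate buffer, at pH 6.5; on this read-out lower numbers stand for lower solubility and higher numbers for higher solubility. Compound 2 `CCOc1cc(CN2CCC(NC(=O)c3cncc(C)c3)CC2)ccc1C` gives > 433 ug/mL, which is the limit of > 433 ug/mL in this assay, at which 1 of the 2 values shown sits, and not a number.

Compound 1 thus holds the only number shown in this assay. Compound 3 `CCOc1cc(CN2CCC(NC(=O)c3ccc(N)nc3)CC2)cc(OCc2ccccc2)c1-c1ccc(F)cc1` differs from compound 1 in one place: phenyl in place of methyl on a saturated chain carbon bound to an oxygen on an aromatic ring. For the measured compounds named here, no measured pair shows this change, so the expected step is a 6.2-fold lower number from compound 1 to compound 3 (0.79 log units; beyond the scatter), a move toward lower solubility beyond the usual scatter. Compound 3 is expected to give 20 ug/mL in this assay, within a range from 5 ug/mL to 80 ug/mL.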

Compound 3, solubility: 5 ug/mL
Beside the measured number, compound 3's estimate is 4.0-fold (0.60 log units) above it; low and high end bracket the measured number.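

In this assay, for the compounds shown here, the change from ethoxy to benzyloxy brings a 25-fold lower number from compound 1 to compound 3 (1.39 log units; beyond the scatter) and gives the first measured pair for this change. It shows that the read-out responds strongly at this position, on a saturated chain carbon bound to an oxygen on an aromatic ring, when phenyl takes the place of methyl. Nothing measured here bears on why the number falls. The compounds shown leave open whether a longer chain, a morpholine or an amine at the same place would keep the number closer to that of compound 1. They also leave open whether the step would keep its size on another core.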